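Replacing the Ring-Nitrogen Substituent of Compound 1

The source may report more compounds than this note shows. Statements on the series, on what has been measured and on what is new or still open speak of the compounds shown alone.

Compound 1 `CN1CCN(c2ccc(Nc3ncc4nc(Nc5ccc(F)cc5)n(CCNS(=O)(=O)C5CC5)c4n3)cc2)CC1` is recorded in a functional assay on A549 cells (Homo sapiens) for antiproliferative activity, read by MTT assay, with a stated time of 72 h (on this read-out higher numbers stand for weaker inhibition and lower numbers for stronger inhibition), as "not determined" (no result reported), so it cannot be placed on any scale; compound 2 `CN1CCN(c2ccc(Nc3ncc4nc(Nc5ccccc5)n([C@@H]5CCNC5)c4n3)cc2)CC1` is likewise recorded in this assay as "not determined" (no result reported). Only compound 3 `CN1CCN(c2ccc(Nc3ncc4nc(Nc5ccccc5)n([C@H]5CCN(S(=O)(=O)C6CC6)C5)c4n3)cc2)CC1` carries a number: in this assay compound 3 gives 540 nM. Compound 4 `CN1CCN(c2ccc(Nc3ncc4nc(Nc5ccc(F)cc5)n(-c5cccc(NC(=O)CO)c5)c4n3)cc2)CC1` differs from compound 1 in a single place: 3-(((hydroxymethyl)carbonyl)amino)phenyl in place of 2-((cyclopropylsulfonyl)amino)ethyl on an aromatic nitrogen. Within the data shown here, with no value for compound 1, no step from compound 1 to compound 4 can be stated, and neither its size nor its direction follows from the data; the one anchor on the shared core is compound 3 at 540 nM. On that basis compound 4 is expected to give about 500 nM in this assay, with an estimated range from 100 nM to 3000 nM.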

Compound 4, half-maximal inhibitory concentration: 1510 nM
Beside the measured number, compound 4's estimate is 3.0-fold (0.48 log units) below it; the measured number falls inside the stated range.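

Among these compounds, compound 1 has no single number in this assay and no step from it to compound 4 can be read. As far as these compounds go, whether 3-(((hydroxymethyl)carbonyl)amino)phenyl strengthens or weakens inhibition relative to 2-((cyclopropylsulfonyl)amino)ethyl stays open. No evidence on a cause is available here.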